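The source may hold more compounds than are shown below. What is called first, only, known or untested is meant among the compounds shown, and "the series" means these compounds.

Measured so far in a physicochemical assay for lipophilicity, read by HPLC, measured as octanol-water partition; on this read-out lower numbers stand for lower lipophilicity and higher numbers for higher lipophilicity:
Compound 1 `Nc1cccc(C(=O)N/N=C/c2ccc3no[n+]([O-])c3c2)c1` gives 1.4
Compound 2 `O=C(N/N=C/c1ccc2no[n+]([O-])c2c1)c1cccc(O)c1` gives 1.2

On these two numbers, compound 2 at 1.2 cannot be told apart from compound 1. Compound 3 `O=C(N/N=C/c1ccc2no[n+]([O-])c2c1)c1ccc(O)cc1` has 4-hydroxyphenyl in place of 3-hydroxyphenyl on a carbonyl carbon as its one difference. Among the compounds with values here, the only measured step is a number 0.20 log units lower from compound 1 to compound 2 (within the scatter) for hydroxy in place of amino on an aromatic carbon, a different kind of change, so it offers only weak guidance. No step beyond the scatter is therefore expected, and the expected step is no change at the digits printed from compound 2 to compound 3 (within the scatter) in this assay here. The estimate for compound 3 is 1.2 with an expected range of 0.9 to 1.5 on this scale.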

Compound 3, partition coefficient: 1.2
For compound 3 middle estimate and measured number coincide at the digits printed; low and high end bracket the measured number.
By their numbers in this assay, from the lowest: compounds 2, 3 and 1 (each within the scatter of the next).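

Within the data shown here, on this assay the swap of 3-hydroxyphenyl for 4-hydroxyphenyl on a carbonyl carbon gives no change at the digits printed from compound 2 to compound 3 (within the scatter) and is the first comparison here of the same atoms joined differently. Placing 4-hydroxyphenyl on that carbon instead of 3-aminophenyl gives a number 0.20 log units lower from compound 1 to compound 3 (within the scatter) and so leaves all three compounds within the scatter of one another. No measured evidence here offers an explanation for these readings.

Still open, as far as these compounds go, is whether a carboxylic acid or a longer alkyl chain on the aromatic ring would give a step beyond the scatter.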